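The compounds below may be only part of what the source reports. "The series", "measured", "known", "first", "only" and "open" are said of these compounds alone.

Of the compounds shown here, two sharing the same core have been measured so far. Compound 1 `CC1=CC[C@H](C(C)(C)NC(=S)N/N=C/c2ccc(Cl)cc2)CC1` carries a 4-chlorophenyl group, and in a functional assay on U-251 cells (Homo sapiens) for inhibition, read by sulforhodamine B assay, with a stated time of 48 h (a lower number here means a stronger inhibitor of growth, a higher number a weaker inhibitor of growth), compound 1 gives 69500 nM. Compound 2 `CC1=CC[C@H](C(C)(C)NC(=S)N/N=C/c2ccco2)CC1` carries a furan-2-yl group instead, and in this assay compound 2 gives 9700 nM; the step of a 7.2-fold lower number from compound 1 to compound 2 (0.86 log units; beyond the scatter) is the only one known here. Compound 2 thus stands at the lowest of the two numbers, with compound 1 its nearest neighbour at a higher number. Compound 3 `CC1=CC[C@H](C(C)(C)NC(=S)N/N=C/c2cccs2)CC1` differs from compound 2 in one place: thiophen-2-yl in place of furan-2-yl on a carbon with a double bond to nitrogen. Among the measured compounds shown here, no measured step swaps one five-membered aromatic ring for another, so the modest step from compound 1 to compound 2 is only an indirect guide. Because compound 2 gives 9700 nM and the change keeps the ring size and the count of hetero atoms, the expected step in this assay is a 1.2-fold higher number from compound 2 to compound 3 (0.09 log units; within the scatter), not beyond the usual scatter in either direction. Compound 3 is therefore estimated at 12000 nM, within 4000 nM to 40000 nM.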

Compound 3, concentration for 50% growth inhibition: 13500 nM
Compound 3: the middle estimate sits 1.1-fold (0.05 log units) below what was measured; the measured number falls inside the stated range.
By their numbers in this assay, from the lowest: compounds 2 and 3 (each within the scatter of the next); then compound 1.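

In this assay, thiophen-2-yl in place of furan-2-yl on a carbon with a double bond to nitrogen gives a 1.4-fold higher number from compound 2 to compound 3 (0.14 log units; within the scatter) and so this exchange of one five-membered aromatic ring for another, with its sulfur in place of oxygen, does not separate the two compounds at this position. The other new step, a 5.1-fold lower number from compound 1 to compound 3 (0.71 log units; beyond the scatter) shows that the distance from the 4-chlorophenyl compound is not peculiar to furan-2-yl, since both five-membered rings shown stand clear of compound 1. No evidence is available that explains either step.

Going by these compounds, it remains open whether this distance belongs to five-membered aromatic rings as such or would also appear with an unsubstituted phenyl, a pyridine or a thiazole at this place. How an open propyl chain or a methyl-bearing furan would stand is equally unknown.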